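The source may hold more compounds than are shown below. What is called first, only, known or untested is meant among the compounds shown, and "the series" means these compounds.

Measured so far:
Compound 1, `COc1ccc(F)cc1C(C)NC(=O)N(C)S(=O)(=O)c1ccc(Cl)cc1`: in a functional assay on thoracic aorta (Rattus norvegicus, strain Wistar), with a stated time of 15 min (on this read-out lower numbers stand for an effect already at smaller amounts and higher numbers for an effect only at larger amounts of compound), compound 1 gives 12600 nM.
Compound 2, `CCOc1ccc(F)cc1C(C)NC(=O)N(C)S(=O)(=O)c1ccc(Cl)cc1`: in this assay compound 2 gives 24500 nM.
Compound 3, `CCOc1ccc(Br)cc1C(C)NC(=O)N(C)S(=O)(=O)c1ccccc1`: in this assay compound 3 gives 19800 nM.

Going by the values given here, the one counted change among the measured compounds, (hydrogen in place of methyl on a saturated chain carbon bound to an oxygen on an aromatic ring), made a 1.9-fold lower number from compound 2 to compound 1 (0.29 log units; within the scatter). The difference between the core of compound 3 and the core of compound 2 is not broken down here; their values show only that the two lie close together.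

Compound 4, `COc1ccc(Br)cc1C(C)NC(=O)N(C)S(=O)(=O)c1ccccc1`, has not been measured. It differs from compound 3 by hydrogen in place of methyl on a saturated chain carbon bound to an oxygen on an aromatic ring, the same change, at the same place, as the one measured. Compound 4 is therefore expected to give about 11000 nM in this assay, an estimated step of a 1.8-fold lower number from compound 3 to compound 4 (0.26 log units; within the scatter), because a 1.9-fold lower number from compound 2 to compound 1 (0.29 log units; within the scatter) was the whole effect of this change when it was measured once, a step within the scatter.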

Compound 4, half-maximal effective concentration: 16800 nM
For compound 4 the middle estimate is 1.5-fold (0.18 log units) below the measured one; the measured number falls inside the stated range.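

In this assay, going from ethoxy to methoxy on the core of compound 3 gave a 1.2-fold lower number from compound 3 to compound 4 (0.07 log units; within the scatter). Set beside the earlier step, the two readings of this change do not differ: the same change on two cores in this assay, a 1.9-fold lower number (0.29 log units; within the scatter) from compound 2 to compound 1 and a 1.2-fold lower number (0.07 log units; within the scatter) from compound 3 to compound 4, 1.6-fold (0.22 log units) apart, within the scatter of two such steps. This shows that the change behaved alike on these two cores, but since each step lies within the scatter, it does not show that the change has a real effect on either core, nor that the same would hold on any other core.

The compounds shown leave open what a longer chain such as propoxy would give in place of ethoxy or methoxy. They also leave open whether a free hydroxyl or an amine there would give a larger step.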